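Swapping Phenyl for Hydroxy: Expected Effect on Cell Growth

A few compounds are considered here, and "the series" means these few. Any claim that something is new, unique, unknown or untested is made for them only; others in the source may bear on it.

Compound 1, `COc1cc(-n2c(-c3ccc(Br)cc3)csc2=S)cc(OC)c1OC`: > 100 ug/mL
Compound 2, `COc1cc(-n2c(-c3ccc(-c4ccccc4)cc3)csc2=S)cc(OC)c1OC`: 45.3 ug/mL

Both compounds were tested in a functional assay on MCF7 cells (Homo sapiens) for cytotoxicity, read by MTT assay, with a stated time of 48 h; a higher number here means a weaker inhibitor, a lower number a stronger inhibitor. For compound 1 the reading of > 100 ug/mL is a limit of the assay, not a number. Going by the values given here, compound 2, with a reading of 45.3 ug/mL, is the only compound with a true number. The other value, that of compound 1, sits at a limit (the limit of > 100 ug/mL in this assay, at which 1 of the 2 values shown sits). Among the compounds with values here, the single measured step, an at least 2.2-fold lower number from compound 1 to compound 2 (0.34 log units; beyond the scatter), is the only guide to how a change at this position moves the result.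

Compound 3, `COc1cc(-n2c(-c3ccc(O)cc3)csc2=S)cc(OC)c1OC`, differs from compound 2 by hydroxy in place of phenyl on an aromatic carbon. Within the data shown here, no measured step involves a hydroxy group. Among the measured compounds shown here, the one step that is known, from bromo to phenyl, lowered the number, and compound 3 gives up that phenyl for another single-atom-anchored group, so the expectation leans toward a higher number, possibly back toward the limit, with wide uncertainty. Compound 3 is therefore estimated at 90 ug/mL, with a plausible range from 40 ug/mL to 200 ug/mL. This expected result corresponds to a step of a 2.0-fold higher number from compound 2 to compound 3 (0.30 log units; within the scatter).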

Compound 3, half-maximal inhibitory concentration: 35.1 ug/mL
Estimate against measurement, compound 3: 2.6-fold (0.41 log units) above; measured number below the stated range.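

In this assay, replacing phenyl with hydroxy gives a 1.3-fold lower number from compound 2 to compound 3 (0.11 log units; within the scatter), so on this aromatic carbon a group of 6 heavy atoms with a ring and a group of 1 heavy atom without one give readings that cannot be told apart. The heavy-atom count of the group therefore does not sort these results, and replacing bromo with hydroxy gives an at least 2.8-fold lower number from compound 1 to compound 3 (0.45 log units; beyond the scatter), a change that, like the one to phenyl, lies beyond the scatter. The reading for compound 1 is a limit and not a number, so the full size of each step away from it stays unknown: the limit of > 100 ug/mL in this assay, at which 1 of the 3 values shown sits.

The compounds shown leave open whether the hydrogen of the hydroxy group matters at this position, a question that a methoxy group in the same place would help to answer, and whether an amine or a carboxylic acid would read like hydroxy and phenyl or like bromo. They also leave open whether any group here can bring the number clearly below those of compound 2 and compound 3.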